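Notes on a halogen swap: compound 2 to compound 3

The source may hold more compounds than are shown below. What is called first, only, known or untested is meant among the compounds shown, and "the series" means these compounds.

Measured so far, in a functional assay on OVCAR-3 cells (Homo sapiens) for inhibition, read by sulforhodamine B assay, with a stated time of 48 h; a lower number here means a stronger inhibitor, a higher number a weaker inhibitor:
- compound 1 `O=c1c(C(=S)Nc2ccccc2)coc2cc(Cl)ccc12`; compound 1 gives > 100000 nM, which is a limit of the assay rather than a number.
- compound 2 `O=c1c(C(=S)Nc2ccccc2)coc2ccccc12`; compound 2 gives 86400 nM.

Among the measured compounds shown here, compound 2 holds the only numerical value in this assay; the other result is a limit. For the measured compounds named here, the single measured step, an at least 1.1-fold lower number from compound 1 to compound 2 (0.06 log units; that floor lies within the scatter), sits against the limit of > 100000 nM in this assay, at which 1 of the 2 values shown sits, and is within scatter. Compound 3 `O=c1c(C(=S)Nc2ccccc2)coc2ccc(F)cc12` carries fluoro in place of hydrogen on an aromatic carbon. Going by the values given here, no measured step covers fluoro entering at this position, so no change beyond scatter is expected in this assay. Compound 3 is estimated at 86000 nM, between 30000 nM and 250000 nM. The expected step is a 1.0-fold lower number from compound 2 to compound 3 (0.00 log units; within the scatter).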

Compound 3, half-maximal inhibitory concentration: > 100000 nM
Compound 3: a limit, no number; the forecaster's own chance of this, stated with the estimate: 35%; at least 1.1-fold (0.06 log units) between middle value and limit.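

In this assay compound 3 gives > 100000 nM, which is a limit and not a number. Among the compounds shown here, this is the first reading at this aromatic carbon: fluoro in place of hydrogen shows no lower number here, and the change can be read only as an at least 1.1-fold higher number from compound 2 to compound 3 (0.06 log units; that floor lies within the scatter). The series now rests largely on that limit: the limit of > 100000 nM in this assay, at which 2 of the 3 values shown sit.

Still open, on these data alone, is whether an amine or a carboxylic acid on this aromatic carbon would give a number clearly lower than that of compound 2. Also open, as far as these compounds go, is whether chloro at this same place would read differently from fluoro.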